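This account rests on a few compounds, and the source may have more. Where it says the series, first, only, none or still open, it means among the compounds named here.

Measured so far in a functional assay on FM3A cells (Mus musculus) for cytotoxicity; on this read-out higher numbers stand for an effect only at larger amounts of compound and lower numbers for an effect already at smaller amounts:
- compound 1 `CCOOC1(OOCC)CCCCCCCCCCC1`: 10000 nM
- compound 2 `CCCCOOC1(OOCCCC)CCCCCCCCCCC1`: 8500 nM
- compound 3 `C=C(C)COOC1(OOCC(=C)C)CCCCCCCCCCC1`: 38000 nM

Compound 2 (8500 nM) lies within the usual scatter of compound 1 (10000 nM). Compound 3 (38000 nM) gives a higher number, beyond the scatter from compound 2, so its effect appears only at larger amounts.

Next in the series is compound 4 `CCCCOOC1(OOC)CCCCCCCCCCC1`, still unmeasured. It differs from compound 2 on one side only: hydrogen in place of propyl on a saturated chain carbon bound to an oxygen on an unsaturated carbon. The same difference reads butoxy to methoxy, with the other butoxyoxy group kept. Among the measured compounds shown here, no measured pair isolates a change of this kind, and no measured compound carries two different chains, so the expectation is indirect.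

The main guide is that compound 1 (10000 nM) and compound 2 (8500 nM) give values within the scatter despite their different saturated chains. Compound 3 (38000 nM) goes against a flat picture across all chains, so the range stays wide, especially towards higher numbers.

In this assay, the expected change is a 1.2-fold higher number from compound 2 to compound 4 (0.07 log units; within the scatter), which is not expected to lie beyond the scatter. For compound 4 the estimated value is 10000 nM, with an expected range from 4500 nM to 28000 nM.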

Compound 4, half-maximal effective concentration: 20000 nM
Compound 4: middle estimate off by 2.0-fold (0.30 log units), on the low side; the measured number falls inside the stated range.
By their numbers in this assay, from the lowest: compounds 2, 1, 4 and 3 (each within the scatter of the next, the first and the last beyond it).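

In this assay, among the compounds shown here, butoxy to methoxy with the other butoxyoxy group kept gives a 2.4-fold higher number from compound 2 to compound 4 (0.37 log units; beyond the scatter), the first step that changes one side alone. The step is modest but beyond the scatter, so this position, a saturated chain carbon bound to an oxygen on an unsaturated carbon, is not indifferent to hydrogen in place of propyl. Here, the shorter chain on one side moves the effect to larger amounts of compound. No measurement shown offers an explanation for this step.

Still open, going by these compounds, is whether the same change would give a similar step with a different group kept on the other side, as this single pair holds only the butoxyoxy group there, and whether intermediate chains such as ethyl or propyl at this position would fall between compound 2 and compound 4. Also open, on these data alone, is how a longer chain such as octyl, a benzyl group, or a chain ending in an amine or a carboxylic acid would read at this position.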